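The source may hold more compounds than are shown below. What is called first, only, known or untested is meant among the compounds shown, and "the series" means these compounds.

Working notes on the series in an assay for inhibition of prostacyclin synthase (Homo sapiens), using microsomes; a higher number here means a weaker inhibitor, a lower number a stronger inhibitor.

Of the compounds shown here, three on the shared core have numbers so far. Compound 1 `CC(C)(Oc1ccccc1[N+](=O)[O-])C1OCC(C/C=C\CCC(=O)O)C(c2cccnc2)O1` gives in this assay < 1000 nM, which is a limit of the assay and not a number; it sits at the limit of < 1000 nM in this assay, at which 1 of the 3 values shown sits. Compound 2 `CC(C)(Oc1ccc(F)cc1[N+](=O)[O-])C1OCC(C/C=C\CCC(=O)O)C(c2cccnc2)O1` gives in this assay 9000 nM. Compound 3 `CC(C)(Cc1ccccc1)C1OCC(C/C=C\CCC(=O)O)C(c2cccnc2)O1` gives in this assay 13000 nM.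

The change fluoro in place of hydrogen on an aromatic carbon produces an at least 9.0-fold higher number from compound 1 to compound 2 (0.95 log units; beyond the scatter); as compound 1 carries a limit, only the lower bound of this step is fixed. The two cores differ by benzyl in place of 2-nitrophenoxy on a saturated chain carbon bound to two saturated chain carbons and a saturated ring carbon, which produces an at least 13-fold higher number from compound 1 to compound 3 (1.11 log units; beyond the scatter). Between compounds 2 and 3 the step is a 1.4-fold higher number from compound 2 to compound 3 (0.16 log units; within the scatter), so these two numbers are not separated.

Compound 4 `CC(C)(Cc1ccc(F)cc1)C1OCC(C/C=C\CCC(=O)O)C(c2cccnc2)O1` is not yet measured. It differs from compound 3 by fluoro in place of hydrogen on an aromatic carbon. This is the same kind of change as that from compound 1 to compound 2, not the same: in compound 1 the place is meta to a nitro group and para to a large group, whereas in compound 3 it is para to a large group only.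

For compound 4 a smaller step than the earlier one is expected, a 1.9-fold higher number from compound 3 to compound 4 (0.28 log units; within the scatter), since the earlier step of an at least 9.0-fold higher number from compound 1 to compound 2 (0.95 log units; beyond the scatter) is open-ended and the cores are separated by the large step of an at least 13-fold higher number from compound 1 to compound 3 (1.11 log units; beyond the scatter). The estimate for compound 4 in this assay is 25000 nM, expected to fall between 8000 nM and 80000 nM.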

Compound 4, half-maximal inhibitory concentration: 2000 nM
For compound 4 the middle estimate is 13-fold (1.10 log units) above the measured one; the whole stated range lies above it.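

In this assay, fluoro in place of hydrogen on an aromatic carbon does not carry over from one core to the other, and the two steps run in opposite directions: the same change on two cores in this assay, an at least 9.0-fold higher number (0.95 log units; beyond the scatter) from compound 1 to compound 2 and a 6.5-fold lower number (0.81 log units; beyond the scatter) from compound 3 to compound 4, at least 58-fold (1.76 log units) apart, beyond the scatter of two such steps.

On the benzyl core the new step is a 6.5-fold lower number from compound 3 to compound 4 (0.81 log units; beyond the scatter), the exchange of the larger group with fluoro on both compounds gives a 4.5-fold lower number from compound 2 to compound 4 (0.65 log units; beyond the scatter), and an at least 2.0-fold higher number from compound 1 to compound 4 (0.30 log units; that floor lies within the scatter), so this last step fixes only a floor and gives no order of compound 1 and compound 4 beyond the scatter. Compound 1 gives < 1000 nM, a limit of the assay and not a number, so the gap between the two fluoro steps is open-ended, and the result shows that the change fails to transfer across these two cores without showing how it would behave on a third: the limit of < 1000 nM in this assay, at which 1 of the 4 values shown sits.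

The compounds shown leave open how the same fluoro change reads on a core carrying a plain phenoxy group, which has neither the nitro group nor the benzyl carbon. They also leave open whether chloro or methoxy, placed para to a large group on compound 3, would move the number as fluoro does.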